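The compounds below may be only part of what the source reports. "The series", "measured", "known", "first", "only" and "open" are said of these compounds alone.

Three compounds have been measured so far in a functional assay on HCT-116 cells (Homo sapiens) for cytotoxicity, read by sulforhodamine B assay; on this read-out lower numbers stand for an effect already at smaller amounts and higher numbers for an effect only at larger amounts of compound:

compound 1 `CCCCCCCCCCCCCC[C@@H](O)[C@@H](O)[C@H](CO)n1cc(CCCC)nn1`: 12900 nM
compound 2 `CCCCCCCCCCCCCC[C@@H](O)[C@@H](O)[C@H](CO)n1cc(CCCCCC)nn1`: 12000 nM
compound 3 `CCCCCCCCCCCCC/C=C/[C@@H](O)[C@H](CO)n1cc(CCCCCC)nn1`: 12500 nM

All three numbers lie close together, and none of the gaps between them goes beyond the usual scatter of this assay. Compound 2 and compound 1 differ in one place only, by hydrogen in place of ethyl on a saturated chain carbon, four bonds along the chain from an aromatic carbon. The step of a 1.1-fold higher number from compound 2 to compound 1 (0.03 log units; within the scatter) is within the scatter, so these two values show no difference worth naming. Compound 3 carries the same chain as compound 2 but a different core; the difference between the two cores is not broken down here.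

Compound 4 `CCCCCCCCCCCCC/C=C/[C@@H](O)[C@H](CO)n1cc(CCCC)nn1` has not yet been measured. For the measured compounds named here, it differs from compound 3 by hydrogen in place of ethyl on a saturated chain carbon, four bonds along the chain from an aromatic carbon, which is the same change, made at the same place, as the one from compound 2 to compound 1. Because that earlier step a 1.1-fold higher number from compound 2 to compound 1 (0.03 log units; within the scatter) stayed within the scatter, the expected step of a 1.0-fold higher number from compound 3 to compound 4 (0.02 log units; within the scatter) is about as small. Compound 4 is therefore expected to give about 13000 nM in this assay, with a likely range from 7000 nM to 25000 nM.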

Compound 4, half-maximal effective concentration: 12900 nM
For compound 4 the middle estimate is 1.0-fold (0.00 log units) above the measured one, within the range that was stated.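

Putting hydrogen in place of ethyl on the core of compound 3 gives a 1.0-fold higher number from compound 3 to compound 4 (0.01 log units; within the scatter) in this assay, so on this core the change makes no difference worth naming. The two cores agree on this change as far as can be read: the same change on two cores in this assay, a 1.1-fold higher number (0.03 log units; within the scatter) from compound 2 to compound 1 and a 1.0-fold higher number (0.01 log units; within the scatter) from compound 3 to compound 4, 1.0-fold (0.02 log units) apart, within the scatter of two such steps. For the compounds shown here, this shows only that a change with no visible effect on one core also had no visible effect on the other; it does not show that a change with a clear effect would carry over equally well, and two cores are a narrow base for any general rule.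

The compounds shown leave open whether a longer chain at this place, or an amine or a carboxylic acid at the end of the chain, would shift the number in this assay. They also leave open whether a step of that kind would come out the same size on both cores.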